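This account rests on a few compounds, and the source may have more. Where it says the series, first, only, none or still open, it means among the compounds named here.

Compound 1 `COc1cc2sn(CCCCN(C)Cc3ccccc3)c(=O)c2cc1OC` and compound 2 `CCN(CCCCn1sc2cc(OC)c(OC)cc2c1=O)Cc1ccccc1` share the same core and differ in a single place on the chain that ends in the amine nitrogen. In an assay on isolated protein for inhibition of Amine oxidase [flavin-containing] A (Homo sapiens), read by fluorescence, with a stated time of 30 min (on this read-out lower numbers stand for stronger inhibition and higher numbers for weaker inhibition), compound 1 gives 8900 nM, and in this assay compound 2 gives 19900 nM. For the measured compounds named here, the only measured step, a 2.2-fold higher number from compound 1 to compound 2 (0.35 log units; beyond the scatter), leaves compound 2 with the higher of the two numbers, that is, the weaker inhibition. Compound 3 `CCN(CCCCn1sc2cc(OC)c(OC)cc2c1=O)Cc1ccc(N(C)C)cc1` differs from compound 2 in one place: dimethylamino in place of hydrogen on an aromatic carbon. Going by the values given here, the one measured step concerns the amine substituent, not the aromatic ring, so no measured step bears directly on this change. Compound 3 is therefore expected to stay near compound 2, with an estimated step of a 1.0-fold higher number from compound 2 to compound 3 (0.00 log units; within the scatter) that need not exceed the usual scatter. The estimate for compound 3 in this assay is 20000 nM, expected to lie between 5000 nM and 60000 nM.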

Compound 3, half-maximal inhibitory concentration: 15900 nM
Compound 3: the middle estimate sits 1.3-fold (0.10 log units) above what was measured; low and high end bracket the measured number.
By their numbers in this assay, from the lowest: compounds 1, 3 and 2 (each within the scatter of the next, the first and the last beyond it).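

Dimethylamino in place of hydrogen on an aromatic carbon, para to a large group, gives a 1.3-fold lower number from compound 2 to compound 3 (0.10 log units; within the scatter) in this assay and is the first change shown on this ring. This ring carbon therefore carries a group of 3 heavy atoms, including 1 hydrogen-bond acceptor, without a difference that can be told apart from the usual scatter, unlike the step at the amine, a 2.2-fold higher number from compound 1 to compound 2 (0.35 log units; beyond the scatter), which goes beyond it. No measurement shown here offers an explanation for this result.

Still open, from the compounds shown here alone, is whether a carboxylic acid or a fluorine atom at this same place would also stay within the scatter of compound 2. Also open, going by these compounds, is whether dimethylamino would give the same result on compound 1.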